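Nitro Enters the Core of Compound 1

The compounds below may be only part of what the source reports. "The series", "measured", "known", "first", "only" and "open" are said of these compounds alone.

compound 1 `O=C(/C=C/OC1=CC=C1)Nc1nc2ccccc2s1` — 781 umol/kg
compound 2 `O=C(/C=C/c1ccc(O)cc1)Nc1nc2ccccc2s1` — 517 umol/kg
compound 3 `O=C(/C=C/c1ccc(Cl)cc1)Nc1nc2ccccc2s1` — 367 umol/kg

Of the compounds shown here, three have been tested in a functional assay on the whole organism (Hindlimb, strain albino) with Mus musculus as the target, in the maximal electroshock model, with a stated time of 0.5 h; a lower number here means that less compound is needed, a higher number that more compound is needed for the effect. Compound 1 gives the highest of the three numbers. Its nearest neighbour is compound 2, with a 1.5-fold lower number from compound 1 to compound 2 (0.18 log units; within the scatter), and its furthest is compound 3, with a 2.1-fold lower number from compound 1 to compound 3 (0.33 log units; beyond the scatter). Between the other two, a 1.4-fold lower number from compound 2 to compound 3 (0.15 log units; within the scatter). All three share the same core and differ only in the group sitting on a double-bonded chain carbon bound to a double-bonded chain carbon.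

Compound 4 `O=C(/C=C/OC1=CC=C1)Nc1nc2ccc([N+](=O)[O-])cc2s1` has not yet been measured. It differs from compound 1 by nitro in place of hydrogen on an aromatic carbon. Among the measured compounds shown here, no measured step changes the core in this way; every step so far swaps the group on the chain, and those steps range from within the scatter to modest. With nothing directly comparable among the measured pairs, the expectation for compound 4 in this assay is a 1.0-fold lower number from compound 1 to compound 4 (0.02 log units; within the scatter), that is, no step beyond the scatter. Compound 4 is therefore estimated at 750 umol/kg, with a range from 350 umol/kg to 1600 umol/kg.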

Compound 4, dose for half-maximal effect: 597 umol/kg
Beside the measured number, compound 4's estimate is 1.3-fold (0.10 log units) above it; the range from low to high includes it.
By their numbers in this assay, from the lowest: compounds 3, 2, 4 and 1 (each within the scatter of the next, the first and the last beyond it).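

Among the compounds shown here, until now every step swapped the group on the chain, so compound 4 gives the first view of a change on the shared core itself. In this assay, placing nitro on an aromatic carbon of the six-membered aromatic ring, part of the fused system, leaves the two compounds within the scatter of each other (a 1.3-fold lower number from compound 1 to compound 4 (0.12 log units; within the scatter)), so this one replacement of hydrogen does not separate them in this test, even though the core now carries a group of several heavy atoms where it had none. Nothing available explains this result or connects it to any particular property of the nitro group.

As far as these compounds go, one substituent at one carbon cannot show whether this part of the core is generally tolerant, so it remains open whether an amine or a chlorine atom on the same carbon would give a step beyond the scatter. From the compounds shown here alone, it is also open whether nitro would give a similar step at another carbon of that ring, or when the chain carries the chloro-substituted aromatic ring of compound 3.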